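Phenyl in place of benzyl: compound 3 awaits measurement

A few compounds are considered here, and "the series" means these few. Any claim that something is new, unique, unknown or untested is made for them only; others in the source may bear on it.

Compound 1 `Cc1cc(=O)c2c(O)c(CN3CCC(N4CCCCC4)CC3)c(O)c([C@H]3CCN(C)C[C@H]3O)c2o1` gives 31% in the test below.
Compound 2 `Cc1cc(=O)c2c(O)c(CN3CCC(Cc4ccccc4)CC3)c(O)c([C@H]3CCN(C)C[C@H]3O)c2o1` gives 21% in the same test.

Both compounds were tested in a functional assay on Caco-2 cells (Homo sapiens) for inhibition, read by MTT assay, with a stated time of 48 h, tested at 10 uM (on this read-out higher numbers stand for more inhibition of growth at the one concentration tested and lower numbers for less inhibition of growth), and only these two numbers are available so far. Compound 2 stands within the scatter of compound 1, so the two values cannot be ranked. Compound 3 `Cc1cc(=O)c2c(O)c(CN3CCC(c4ccccc4)CC3)c(O)c([C@H]3CCN(C)C[C@H]3O)c2o1` has not yet been measured and comes from compound 2 by a single change. That change is phenyl in place of benzyl on a saturated ring carbon and in words it is phenyl in place of benzyl on a saturated ring carbon. Among the measured compounds shown here, the only measured step at that carbon, benzyl in place of piperidin-1-yl on a saturated ring carbon, is a number 10 percentage points lower from compound 1 to compound 2 (within the scatter) and from that step alone none beyond the scatter is expected in this assay for the present change. For the measured compounds named here, one step is thin evidence, and no measured compound shows phenyl at this place. The estimated step is a number 3 percentage points higher from compound 2 to compound 3 (within the scatter) and it is expected to stay within the scatter. For compound 3 the expected value is 24% with an estimated range of 11% to 38% on this read-out.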

Compound 3, percent growth inhibition at one concentration: 21%
Beside the measured number, compound 3's estimate is 3 percentage points above it; the range from low to high includes it.
By their numbers in this assay, from the lowest: compounds 2, 3 and 1 (each within the scatter of the next).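

In this assay, phenyl, with 6 heavy atoms, in place of benzyl, with 7, on the saturated ring carbon gives no change at the digits printed from compound 2 to compound 3 (within the scatter) and so adds a second aromatic group to the comparison at this place. Phenyl in place of piperidin-1-yl gives a number 10 percentage points lower from compound 1 to compound 3 (within the scatter) and thus, like benzyl, this aromatic group cannot be told apart from the saturated ring containing nitrogen, so at this single concentration piperidin-1-yl, benzyl and phenyl show no step beyond the scatter at the carbon three ring bonds from the ring nitrogen. Nothing measured here offers an explanation for how closely these three groups read.

The compounds shown leave open whether a group of another kind on this carbon, such as a carboxylic acid, a primary amine or a longer chain such as 2-phenylethyl, would give a step beyond the scatter. They also leave open whether a phenyl ring carrying a substituent such as methoxy would read apart from plain phenyl, and how the three groups would compare across a range of concentrations.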